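Dropping one bromo from a dibromo anilide core

This account rests on a few compounds, and the source may have more. Where it says the series, first, only, none or still open, it means among the compounds named here.

compound 1 `COc1c(Br)cc(Br)cc1C(=O)Nc1ccccc1` — in an assay on isolated protein for inhibition of thiosulfate sulfurtransferase (Homo sapiens), with a stated time of 60 min, in the absence of a further agent (on this read-out lower numbers stand for stronger inhibition and higher numbers for weaker inhibition), gives > 100000 nM, a limit of the assay
compound 2 `COc1c(Br)cccc1C(=O)Nc1ccccc1` — in this assay gives > 100000 nM, a limit of the assay
compound 3 `O=C(Nc1ccccc1)c1cc(Br)cc(Br)c1` — in this assay gives > 100000 nM, a limit of the assay

For compound 1 the reading is thus only a limit, not a number. The steps a step that the two limits leave unreadable from compound 1 to compound 2 and a step that the two limits leave unreadable from compound 1 to compound 3 cannot be sized because of the limit of > 100000 nM in this assay, at which 3 of the 3 values shown sit. Compound 4 `COc1ccc(Br)cc1C(=O)Nc1ccccc1` differs from compound 1 by hydrogen in place of bromo on an aromatic carbon. The measured steps that bear on this change, hydrogen in place of bromo and hydrogen in place of methoxy, are both unreadable, so in this assay no direction and no size beyond the scatter can be foreseen. Compound 4 is therefore expected to give 150000 nM (estimated range 50000 nM to 500000 nM). The expected step that the limit leaves unreadable from compound 1 to compound 4 is estimated to stay within the scatter.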

Compound 4, half-maximal inhibitory concentration: > 100000 nM
Compound 4: a limit, no number; the forecaster's own chance of this, stated with the estimate: 85%; the middle value lies beyond the limit too.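

Among the compounds shown here, compound 4, like compound 1, sits at a limit and gives no number, so no step from compound 1 to compound 4 can be read: the limit of > 100000 nM in this assay, at which 4 of the 4 values shown sit. The compounds shown leave open what either bromo group or the methoxy group contributes to inhibition.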